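The compounds below may be only part of what the source reports. "The series", "measured", "known", "first", "only" and "open" are said of these compounds alone.

In an ADME assay on Vero 76 cells (Chlorocebus sabaeus) for cytotoxicity, read by microscopy (a higher number here means that more compound is tolerated, a lower number that less compound is tolerated), three compounds sharing one core have been read so far. Compound 1 `CC(C)C(Nc1nc(Cl)nc2c1ncn2[C@H]1[C@H](O)[C@H](O)[C@]2(CO)C[C@H]12)C(C)C` gives > 100000 nM, which is a limit of the assay and not a number. Compound 2 `OC[C@@]12C[C@@H]1[C@@H](n1cnc3c(NC(C4CCC4)C4CCC4)nc(Cl)nc31)[C@H](O)[C@@H]2O` gives a true number, 50000 nM. Compound 3 `CC(C)(O)[C@@H](Nc1nc(Cl)nc2c1ncn2[C@H]1[C@H](O)[C@H](O)[C@]2(CO)C[C@H]12)C1CC1` gives > 100000 nM, again a limit. That places compound 3 at the limit of > 100000 nM in this assay, at which 2 of the 3 values shown sit, so no exact starting number exists for the next step.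

Compound 4 `CC(C)(C)[C@H](Nc1nc(Cl)nc2c1ncn2[C@H]1[C@H](O)[C@H](O)[C@]2(CO)C[C@H]12)C1CC1` carries 1-cyclopropyl-2,2-dimethylpropyl in place of 1-cyclopropyl-2-hydroxy-2-methylpropyl on a nitrogen on an aromatic ring.

Going by the values given here, the only guides are the changes at this same place. One is an at least 2.0-fold lower number from compound 1 to compound 2 (0.30 log units; that floor lies within the scatter), and another is an at least 2.0-fold higher number from compound 2 to compound 3 (0.30 log units; that floor lies within the scatter). The third, a step that the two limits leave unreadable from compound 1 to compound 3, gives no size at all. None of these shows a change clearly beyond the scatter, so in this assay only a small drop is expected, possibly none beyond the scatter.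

The expected step is an at least 1.2-fold lower number from compound 3 to compound 4 (0.09 log units; that floor lies within the scatter). For compound 4 the estimated value is 80000 nM, with an expected range from 35000 nM to 100000 nM.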

Compound 4, half-maximal cytotoxic concentration: > 100000 nM
Compound 4: no number, only a limit; the forecaster's own chance of this, stated with the estimate: 55%; middle value at least 1.2-fold (0.09 log units) away from the limit.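

In this assay compound 4 gives > 100000 nM, a limit of the assay and not a number, so 1-cyclopropyl-2,2-dimethylpropyl, which has no hydrogen-bond donor or acceptor, reads the same way as the hydroxyl-bearing group it replaces. The steps to compound 4 from compound 1 and from compound 3 cannot be read, and the only readable one is an at least 2.0-fold higher number from compound 2 to compound 4 (0.30 log units; that floor lies within the scatter). Any real difference among compound 1, compound 3 and compound 4 therefore stays hidden, as most of the series now rests at one limit: the limit of > 100000 nM in this assay, at which 3 of the 4 values shown sit.

Going by these compounds alone, compound 2 remains the only one with a true number, so the size of any effect of this change on tolerated compound stays unknown. On these data alone, it also remains open how an amine or a carboxylic acid on this nitrogen's side chain would read.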